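A Trifluoromethyl Swap in a Growth Inhibition Series

The source may hold more compounds than are shown below. What is called first, only, known or untested is meant among the compounds shown, and "the series" means these compounds.

In a functional assay on SiHa cells (Homo sapiens) for inhibition, read by sulforhodamine B assay (a lower number here means a stronger inhibitor of growth, a higher number a weaker inhibitor of growth), compound 1 (`FC(F)(F)c1ccc(-c2ccc(-c3ccc(-c4nc5ccccc5[nH]4)cc3)cc2)cc1`) gives 100000 nM in this test. Compound 2 (`Oc1cccc2[nH]c(-c3ccc(-c4ccc(-c5ccccc5)cc4)cc3)nc12`) gives 9710 nM and compound 3 (`Oc1cccc2[nH]c(-c3ccc(-c4ccc(-c5ccc(F)cc5)cc4)cc3)nc12`) gives 9100 nM as its reading. Compound 3 therefore stands level with compound 2 and clearly under compound 1, by a gap beyond the scatter.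

Compound 4 (`Oc1cccc2[nH]c(-c3ccc(-c4ccc(-c5ccc(C(F)(F)F)cc5)cc4)cc3)nc12`) puts trifluoromethyl in place of fluoro on an aromatic carbon, para to a large group. Within the data shown here, one measured step bears directly on this spot: fluoro replacing hydrogen gave a 1.1-fold lower number from compound 2 to compound 3 (0.03 log units; within the scatter) and so changed nothing measurable. Compound 1 also carries trifluoromethyl, but it differs from compound 2 in more than one place, so it isolates no single change. With so little evidence, no step beyond the scatter is expected in this assay here, and the range stays wide. This estimate for compound 4 means a 1.1-fold higher number from compound 3 to compound 4 (0.04 log units; within the scatter) as the expected step. The estimated value for compound 4 is 10000 nM with an expected range from 4000 nM to 30000 nM in this test.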

Compound 4, concentration for 50% growth inhibition: 3720 nM
Compound 4: the middle estimate sits 2.7-fold (0.43 log units) above what was measured, and the stated range ends above it.
By their numbers in this assay, from the lowest: compound 4; then compounds 3 and 2 (each within the scatter of the next); then compound 1.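

At the position para to a large group, fluoro left the reading unchanged, but trifluoromethyl moves it in this assay: replacing fluoro gives a 2.4-fold lower number from compound 3 to compound 4 (0.39 log units; beyond the scatter), and replacing hydrogen gives a 2.6-fold lower number from compound 2 to compound 4 (0.42 log units; beyond the scatter). The new compound also allows a clean look at the hydroxy with trifluoromethyl held in place, and adding it gives a 27-fold lower number from compound 1 to compound 4 (1.43 log units; beyond the scatter), a much larger step than either change at the para position. Nothing measured here explains why trifluoromethyl shifts the number while fluoro does not.

As far as these compounds go, it remains open whether a nitrile, a methoxy or a tert-butyl group at this place would lower the number further or leave it level with fluoro. Also open, from the compounds shown here alone, is whether the hydroxy would give a step of similar size with hydrogen or fluoro at this position.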